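A few compounds are considered here, and "the series" means these few. Any claim that something is new, unique, unknown or untested is made for them only; others in the source may bear on it.

In an assay on HeLa cells for inhibition of sphingosine-1-phosphate transporter SPNS2 (Mus musculus), read by LC-MS, tested at 2 uM (on this read-out higher numbers stand for more inhibition at the one concentration tested (going by the name of the read-out) and lower numbers for less inhibition), three compounds have been measured. Compound 1, `CCCCCCCCCCc1ccc(-c2noc(CC(O)CN(C)C)n2)cc1`, gives 61%; compound 2, `CCCCCCCCCCc1ccc(-c2cnn(CCCN)c2)cc1`, gives 50%; and compound 3, `CCCCCCc1ccc(-c2noc(CCCN)n2)cc1`, gives 55%. On this assay compound 3 stands second of the three numbers, but its nearest neighbour, compound 2, is only a few points lower and compound 1 only a few points higher, and both of these gaps lie within the scatter of the measurement, so no one of the three can be called stronger or weaker than the others on what is shown.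

Compound 4, `CCCCCCCCCCCc1ccc(-c2noc(CCCN)n2)cc1`, has not yet been measured. It differs from compound 3 in one place: pentyl in place of hydrogen on a saturated chain carbon, six bonds along the chain from an aromatic carbon. Among the compounds with values here, no measured pair shows this change by itself, so its size has to be guessed. Since compounds 1 and 2, which carry longer chains than compound 3, give numbers within the scatter of compound 3, the expectation is a step of a number 5 percentage points higher from compound 3 to compound 4 (within the scatter), not beyond the scatter. The estimate for compound 4 in this assay is 60%, expected to fall between 42% and 78%.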

Compound 4, a percentage reported as inhibition, at one concentration (the size of the read-out at that concentration, not a potency): 49%
Compound 4: middle estimate off by 11 percentage points, on the high side, and the stated range covers the measured number.
By their numbers in this assay, from the lowest: compounds 4, 2, 3 and 1 (each within the scatter of the next, the first and the last beyond it).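

This is the first pair shown that differs in one place only, so the effect of lengthening the chain can now be read by itself. In this assay, pentyl in place of hydrogen on a saturated chain carbon, six bonds along the chain from an aromatic carbon, reads as a number 6 percentage points lower from compound 3 to compound 4 (within the scatter) and so cannot be told apart from the usual spread of repeated measurements at this one concentration. Nothing at hand bears on why this is so.

The compounds shown leave open whether a still longer chain at this position, tested against compound 4, would produce a difference that stands clear of the scatter. They also leave open what a carboxylic acid in place of the amine would do on either chain.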